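Working notes on compounds 1 to 4, antiproliferative series

The compounds below may be only part of what the source reports. "The series", "measured", "known", "first", "only" and "open" are said of these compounds alone.

Measured so far:
- compound 1 `COc1cc(/C=N/n2c(-c3ccccc3)n[nH]c2=S)ccc1O` gives 19600 nM in a functional assay on Bel-7402 cells (Homo sapiens) for antiproliferative activity, read by MTT assay, with a stated time of 24 h; on this read-out lower numbers stand for stronger inhibition and higher numbers for weaker inhibition
- compound 2 `CC(=O)O[C@@H]1OC(n2nc(-c3ccccc3)n(/N=C/c3ccc(O)cc3)c2=S)[C@@H](C(C)=O)[C@H](OC(C)=O)[C@H]1OC(C)=O` gives 11300 nM in this assay
- compound 3 `S=c1[nH]nc(-c2ccccc2)n1/N=C/c1ccccc1` gives 22500 nM in this assay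

Compound 2 has the lowest of the three numbers in this assay, yet its gap to compound 1 and its gap to compound 3 both stay within the scatter, so no order among the three can be read from these values. Compound 4 `CC(=O)O[C@@H]1OC(n2nc(-c3ccccc3)n(/N=C/c3ccc(Cl)cc3)c2=S)[C@@H](C(C)=O)[C@H](OC(C)=O)[C@H]1OC(C)=O` differs from compound 2 in one place: chloro in place of hydroxy on an aromatic carbon. For the measured compounds named here, no measured pair differs in a single place, so there is no measured step to lean on. Because compound 2 gives 11300 nM in this assay and that value sits within the scatter of the other two despite differing substitution, the step is expected to be small, a 1.1-fold higher number from compound 2 to compound 4 (0.03 log units; within the scatter), none beyond the scatter. Compound 4 is estimated at 12000 nM, within 5000 nM to 30000 nM.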

Compound 4, half-maximal inhibitory concentration: 17400 nM
Beside the measured number, compound 4's estimate is 1.5-fold (0.16 log units) below it; low and high end bracket the measured number.
By their numbers in this assay, from the lowest: compounds 2, 4, 1 and 3 (each within the scatter of the next).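

For the compounds shown here, the exchange of 4-hydroxyphenyl for 4-chlorophenyl gives the first single-place step, a 1.5-fold higher number from compound 2 to compound 4 (0.19 log units; within the scatter) in this assay. At this position, on an aromatic carbon para to a large group, replacing hydroxy with chloro therefore produces no change readable beyond the scatter. No measured data bear on the reason for this outcome. As far as these compounds go, whether an amine or a carboxylic acid at this position would shift the number beyond the scatter remains open, as does whether the same exchange would read alike on the core of compound 1.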